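A few compounds are considered here, and "the series" means these few. Any claim that something is new, unique, unknown or untested is made for them only; others in the source may bear on it.

Measured compounds:
compound 1 `CC(C(=O)NCc1ccc(C(F)(F)F)nc1N(Cc1ccccc1)S(C)(=O)=O)c1ccc(NS(C)(=O)=O)c(F)c1`, in an assay on CHO cells for displacement of a labelled ligand from transient receptor potential cation channel subfamily V member 1 (Homo sapiens), read by scintillation counting, with a stated time of 60 min (on this read-out higher numbers stand for weaker inhibition and lower numbers for stronger inhibition), compound 1 gives 101 nM
compound 2 `CC(C(=O)NCc1ccc(C(F)(F)F)nc1N(Cc1ccccc1)S(=O)(=O)c1ccc(F)cc1)c1ccc(NS(C)(=O)=O)c(F)c1`, in this assay compound 2 gives 1.56 nM

Among the measured compounds shown here, compound 2 stands at the lowest number of the two measured in this assay; its only neighbour is compound 1, and the one measured step, a 65-fold lower number from compound 1 to compound 2 (1.81 log units; beyond the scatter), separates them by a margin well beyond the scatter. That step concerns the group on the sulfonyl sulfur and nothing else.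

Compound 3 `CC(C(=O)NCc1ccc(C(F)(F)F)nc1N(Cc1ccc(F)cc1)S(=O)(=O)c1ccc(F)cc1)c1ccc(NS(C)(=O)=O)c(F)c1` differs from compound 2 by fluoro in place of hydrogen on an aromatic carbon, that is, a fluoro in place of hydrogen on an aromatic carbon of the benzyl ring, para to a large group. For the measured compounds named here, no measured pair touches this part of the molecule, so the step from compound 1 to compound 2 bears on it only as a sign that the series tolerates change at the sulfonamide nitrogen without loss. A single fluoro on the benzyl ring is a small change; the expected step, a 1.0-fold lower number from compound 2 to compound 3 (0.02 log units; within the scatter), is one that should stay within the scatter of this assay, in either direction.

Compound 3 is therefore estimated at 1.5 nM in this assay, within the range 0.5 nM to 5 nM.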

Compound 3, inhibition constant: 0.71 nM
Beside the measured number, compound 3's estimate is 2.1-fold (0.32 log units) above it; the range from low to high includes it.
By their numbers in this assay, from the lowest: compound 3; then compound 2; then compound 1.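

Fluoro in place of hydrogen on an aromatic carbon of the benzyl ring, para to a large group, gives a 2.2-fold lower number from compound 2 to compound 3 (0.34 log units; beyond the scatter) in this assay and so registers on this read-out, though only modestly. Among the compounds shown here, this is the first reading on the benzyl ring itself: 4-fluorobenzyl is accepted in place of benzyl with the 4-fluorophenyl on the sulfonyl sulfur kept, and the number moves down rather than up, which the earlier change at the sulfonyl sulfur could not show. Nothing measured on these compounds accounts for the step.

Whether this step belongs to fluoro in particular remains open, as chloro, methoxy, a nitrile and an amine at the same place on the benzyl ring are not among the compounds shown. Also open, as far as these compounds go, is whether the step would hold with methyl in place of 4-fluorophenyl on the sulfonyl sulfur, and whether a longer chain or a carboxylic acid in place of the benzyl group would be accepted at all.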